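A few compounds are considered here, and "the series" means these few. Any claim that something is new, unique, unknown or untested is made for them only; others in the source may bear on it.

Measured so far in a functional assay on A2780 cells (Homo sapiens) for antiproliferative activity, read by MTT assay, with a stated time of 3 days; a lower number here means a stronger inhibitor, a higher number a weaker inhibitor:

compound 1, `CCCCOC1(c2ccc(Br)cc2)SC=C(C)n2c1noc2=O`: 82000 nM
compound 2, `CCCCCCCCCCCCCCCCCCOC1(c2ccc(Br)cc2)SC=C(C)n2c1noc2=O`: > 100000 nM, a limit of the assay and not a number
compound 3, `CC1=CSC(O)(c2ccc(C)cc2)c2noc(=O)n21`: > 100000 nM, a limit of the assay and not a number

Among the compounds with values here, compound 1 is thus the only member of the series with a number in this assay; the other two values are limits of the assay, and the limit of > 100000 nM in this assay, at which 2 of the 3 values shown sit, is where two of the three values sit. Compound 1 itself is a weak inhibitor in this assay, so the whole series sits at the high end of the range that can be measured.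

The next compound, compound 4, `CCCCOC1(c2ccc(Cl)cc2)SC=C(C)n2c1noc2=O`, differs from compound 1 in one place: chloro in place of bromo on an aromatic carbon. The rest of the core and the butoxy chain stay as in compound 1.

Within the data shown here, no step between two measured compounds is known, so the size of this exchange cannot be read from the series. The step of a 1.1-fold higher number from compound 1 to compound 4 (0.04 log units; within the scatter) is expected to lie within the scatter, with no clear direction. Compound 4 is accordingly expected to give 90000 nM in this assay, in a range from 40000 nM to 200000 nM, with a fair chance that only a limit is reported.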

Compound 4, half-maximal inhibitory concentration: 89000 nM
Beside the measured number, compound 4's estimate is 1.0-fold (0.00 log units) above it; low and high end bracket the measured number.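

Within the data shown here, the first readable step in this assay is the exchange of 4-bromophenyl to 4-chlorophenyl, with a 1.1-fold higher number from compound 1 to compound 4 (0.04 log units; within the scatter). At this place on the aromatic ring, para to a large group, bromo and chloro cannot be told apart in this read-out, and the exchange gives no direction to follow for this position. Compound 4 adds a second number to the series, but the readings still lie at the high end of the measurable range, leaving little room to resolve a further weakening: the limit of > 100000 nM in this assay, at which 2 of the 4 values shown sit.

The steps that involve compound 2 or compound 3 cannot be read, as each of these compounds carries only a limit of the assay and not a number. Still open, from the compounds shown here alone, is whether any group at this same place can move the number beyond the scatter, for example an amine, a carboxylic acid or a methoxy group, and whether an ether chain of intermediate length in place of the butoxy chain gives a readable value.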